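The source may hold more compounds than are shown below. What is called first, only, known or untested is meant among the compounds shown, and "the series" means these compounds.

The three measured compounds share one core and differ only in the aryl group attached to an aromatic nitrogen. Compound 1 `N#CC1=C(N)Oc2c(c3nc4ccccc4nc3c3ccccc23)C12C(=O)N(Cc1cnnn1-c1ccc(F)cc1)c1ccccc12` carries a 4-fluorophenyl there. In a functional assay on A549 cells (Homo sapiens) for antiproliferative activity, read by MTT assay, with a stated time of 48 h (on this read-out lower numbers stand for stronger inhibition and higher numbers for weaker inhibition), compound 1 gives only a limit of the assay, > 50000 nM, so its standing among the numbers shown cannot be read more closely than that. Compound 2 `N#CC1=C(N)Oc2c(c3nc4ccccc4nc3c3ccccc23)C12C(=O)N(Cc1cnnn1-c1ccccc1Cl)c1ccccc12` carries a 2-chlorophenyl in that place, and in this assay compound 2 gives 42600 nM. Compound 3 `COc1ccc(-n2nncc2CN2C(=O)C3(C(C#N)=C(N)Oc4c3c3nc5ccccc5nc3c3ccccc43)c3ccccc32)cc1` carries a 4-methoxyphenyl. In this assay compound 3 likewise gives only a limit, > 50000 nM. The measured steps are small or unreadable: an at least 1.1-fold lower number from compound 1 to compound 2 (0.06 log units; that floor lies within the scatter), a step that the two limits leave unreadable from compound 1 to compound 3 and an at least 1.1-fold higher number from compound 2 to compound 3 (0.06 log units; that floor lies within the scatter), which follows from the limit of > 50000 nM in this assay, at which 2 of the 3 values shown sit.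

Compound 4 `N#CC1=C(N)Oc2c(c3nc4ccccc4nc3c3ccccc23)C12C(=O)N(Cc1cnnn1-c1ccc([N+](=O)[O-])cc1)c1ccccc12` is reached from compound 1 by the change (nitro in place of fluoro on an aromatic carbon). All three measured steps alter the same aryl group on the aromatic nitrogen, and none of them moves the number clearly, so no step beyond the scatter is expected in this assay here either. Compound 4 is therefore expected to sit near 45000 nM, with a range from 15000 nM to 150000 nM. That estimate for compound 4 means an at least 1.1-fold lower number from compound 1 to compound 4 (0.04 log units; that floor lies within the scatter), expected to lie within the scatter, with a fair chance that only a limit is reported.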

Compound 4, half-maximal inhibitory concentration: > 50000 nM
Compound 4: only a limit was reported; the forecaster's own chance of this, stated with the estimate: 55%; at least 1.1-fold (0.04 log units) between middle value and limit.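

In this assay compound 4 gives only a limit, > 50000 nM. Going by these compounds alone, the one readable step is an at least 1.1-fold higher number from compound 2 to compound 4 (0.06 log units; that floor lies within the scatter), and the other steps to this compound cannot be read. Fluoro gives way here to nitro, which brings three heavy atoms and two hydrogen-bond acceptors to the aromatic carbon para to a large group, yet this larger change opens no readable difference, and the comparison still ends at the same boundary of the assay: the limit of > 50000 nM in this assay, at which 3 of the 4 values shown sit.

The compounds shown leave open whether an amine or a carboxylic acid on this phenyl ring, or a longer chain in place of the aryl group on the aromatic nitrogen, would give a number clearly apart from those seen so far. They also leave open where the true values of compound 1, compound 3 and compound 4 lie, so no order among these three can be stated.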